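Replacing the Acetoxyethyl Ester Side Chain of Compound 1

The source may hold more compounds than are shown below. What is called first, only, known or untested is meant among the compounds shown, and "the series" means these compounds.

Compound 1 `CC(=O)OCCC(=O)O[C@H](CC=C(C)C)C1=CC(=O)c2c(O)ccc(O)c2C1=O` serves as the reference point in a small set of esters and ethers built on one shared core. In a functional assay on HeLa cells (Homo sapiens) for cytotoxicity, read by MTT assay (on this read-out higher numbers stand for weaker inhibition and lower numbers for stronger inhibition), compound 1 gives 17300 nM. Compound 3 `CCC(CO[C@H](CC=C(C)C)C1=CC(=O)c2c(O)ccc(O)c2C1=O)OC(C)=O` gives 44000 nM in this assay. Compound 2 `CCCCCCC(C)(O)CC(=O)O[C@H](CC=C(C)C)C1=CC(=O)c2c(O)ccc(O)c2C1=O` reaches only the limit of > 100000 nM in this assay, so no number is known for it. Among the two numbers available, compound 1 stands lowest, with compound 3 as its nearest neighbour.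

Compound 4 `CC(C)=CC[C@@H](OC(=O)C1CCOC1)C1=CC(=O)c2c(O)ccc(O)c2C1=O` has not yet been measured. It differs from compound 1 in one place: oxolan-3-yl in place of 2-acetoxyethyl on a carbonyl carbon. Among the measured compounds shown here, two measured steps bear on this kind of change, both touching the chain attached through the ester oxygen. The step of an at least 5.7-fold higher number from compound 1 to compound 2 (0.76 log units; beyond the scatter) and the step of a 2.5-fold higher number from compound 1 to compound 3 (0.41 log units; beyond the scatter) both move away from compound 1 toward higher numbers, although the first of them rests on a limit (the limit of > 100000 nM in this assay, at which 1 of the 3 values shown sits). Both changes of this chain that have been measured so far weakened the effect; no measured change improved it. A modest rise in the number is therefore expected for the step of a 1.8-fold higher number from compound 1 to compound 4 (0.27 log units; within the scatter). Compound 4 is accordingly estimated at 32000 nM, within a range from 12000 nM to 85000 nM.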

Compound 4, half-maximal inhibitory concentration: 73500 nM
Estimate against measurement, compound 4: 2.3-fold (0.36 log units) below, and the stated range covers the measured number.
By their numbers in this assay, from the lowest: compound 1; then compounds 3 and 4 (each within the scatter of the next). At a limit, above all of these: compound 2.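

The ring does not rescue this position: with the five-membered non-aromatic oxolan-3-yl on the carbonyl carbon, this assay gives a 4.2-fold higher number from compound 1 to compound 4 (0.63 log units; beyond the scatter), so a cyclic replacement for 2-acetoxyethyl moves the same way as the open-chain changes of compounds 2 and 3, and none of the three goes against that direction. Ester and ether forms are not separated here, as (oxolan-3-yl)carbonyl in place of 2-acetoxybutyl on an oxygen on a saturated carbon gives a 1.7-fold higher number from compound 3 to compound 4 (0.22 log units; within the scatter). With oxolan-3-yl in place of 2-hydroxy-2-methyloctyl on a carbonyl carbon, the data give an at least 1.3-fold lower number from compound 2 to compound 4 (0.13 log units; that floor lies within the scatter). That step gives no firm size, since compound 2 stands only at a limit: the limit of > 100000 nM in this assay, at which 1 of the 4 values shown sits.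

The compounds shown leave open whether the ring itself or the loss of the acetoxy group accounts for the rise from compound 1. Also open, as far as these compounds go, is how an amine, a carboxylic acid or a six-membered ring such as oxan-4-yl on the carbonyl carbon would read, and whether any group there can outdo compound 1, which gives 17300 nM.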